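This account rests on a few compounds, and the source may have more. Where it says the series, first, only, none or still open, it means among the compounds named here.

Compound 1 `Cc1nnc(SCC(=O)N/N=c2/scc(-c3ccccc3)n2-c2ccccc2)s1` gives 197 ug/mL in an ADME assay on NIH3T3 cells (Mus musculus) for cytotoxicity, read by MTT assay, with a stated time of 24 h; on this read-out lower numbers stand for stronger inhibition and higher numbers for weaker inhibition.
Compound 2 `Cc1nnc(SCC(=O)N/N=c2/scc(-c3ccc(C#N)cc3)n2-c2ccccc2)s1` reaches only a limit of this assay, < 3.9 ug/mL.
Compound 3 `O=C(CSc1nnnn1-c1ccccc1)N/N=c1/scc(-c2ccccc2)n1-c1ccccc1` gives 417 ug/mL in this assay.

Two single changes connect these three. From compound 1 to compound 2 the change is cyano in place of hydrogen on an aromatic carbon, and it brings an at least 50-fold lower number from compound 1 to compound 2 (1.70 log units; beyond the scatter); the value of compound 2 is a limit, as noted in the limit of < 3.9 ug/mL in this assay, at which 1 of the 3 values shown sits. From compound 1 to compound 3 the cores differ by 1-phenyl-1H-tetrazol-5-yl in place of 5-methyl-1,3,4-thiadiazol-2-yl on a sulfur, which gives a 2.1-fold higher number from compound 1 to compound 3 (0.33 log units; beyond the scatter), so compound 3 stands at the highest number of the two measured numbers.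

Compound 4 `N#Cc1ccc(-c2cs/c(=N/NC(=O)CSc3nnnn3-c3ccccc3)n2-c2ccccc2)cc1` is not yet measured. It differs from compound 3 by cyano in place of hydrogen on an aromatic carbon, the same change already seen from compound 1 to compound 2, made on the core of compound 3 rather than that of compound 1. The place of the change reads the same in both cases. An expectation for compound 4 rests on that earlier step: since the same change gave an at least 50-fold lower number from compound 1 to compound 2 (1.70 log units; beyond the scatter), compound 4 is expected to show a 70-fold lower number from compound 3 to compound 4 (1.84 log units; beyond the scatter) in this assay. Compound 4 is therefore estimated at 6 ug/mL, within 2 ug/mL to 30 ug/mL.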

Compound 4, half-maximal inhibitory concentration: 453 ug/mL
Compound 4: middle estimate off by 76-fold (1.88 log units), on the low side; measured number outside the range, above it.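

In this assay, cyano in place of hydrogen on an aromatic carbon does not carry over from the core of compound 1 to the core of compound 3: on the latter it gives a 1.1-fold higher number from compound 3 to compound 4 (0.04 log units; within the scatter), and the two steps clearly part: the same change on two cores in this assay, an at least 50-fold lower number (1.70 log units; beyond the scatter) from compound 1 to compound 2 and a 1.1-fold higher number (0.04 log units; within the scatter) from compound 3 to compound 4, at least 54-fold (1.73 log units) apart, beyond the scatter of two such steps. The same split appears when the sulfur substituents are compared, with 1-phenyl-1H-tetrazol-5-yl in place of 5-methyl-1,3,4-thiadiazol-2-yl giving an at least 110-fold higher number from compound 2 to compound 4 (2.06 log units; beyond the scatter) on the cores that carry the cyano, against a much smaller step on those that do not: the same change on two cores in this assay, a 2.1-fold higher number (0.33 log units; beyond the scatter) from compound 1 to compound 3 and an at least 110-fold higher number (2.06 log units; beyond the scatter) from compound 2 to compound 4, at least 54-fold (1.73 log units) apart, beyond the scatter of two such steps. Among the compounds shown here, the value of compound 2 is a limit, so both gaps are bounds and not exact sizes, and the two pairs show only that this step depends on the core, not why it does: the limit of < 3.9 ug/mL in this assay, at which 1 of the 4 values shown sits.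

The compounds shown leave open whether an amine or a carboxylic acid in place of the cyano would split the two cores in the same way. They also leave open how the cyano step reads with a 1-methyl-1H-tetrazol-5-yl group on the sulfur.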